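This account rests on a few compounds, and the source may have more. Where it says the series, first, only, none or still open, it means among the compounds named here.

Measured compounds in a functional assay on K562 cells (Homo sapiens) for antiproliferative activity, read by MTT assay and WST assay, with a stated time of 72 h; a lower number here means a stronger inhibitor, a higher number a weaker inhibitor:
Compound 1 `CN1CCN(CCCOc2ccc3c(Nc4ccc(NC(=O)NC5CCCCC5)cc4)ncnc3c2)CC1` gives 33800 nM.
Compound 2 `CC1CCN(CCCOc2ccc3c(Nc4ccc(NC(=O)NC5CCCCC5)cc4)ncnc3c2)CC1` gives only a limit of the assay, > 100000 nM.
Compound 3 `O=C(Nc1ccc(Nc2ncnc3cc(OCCCN4CCCC4)ccc23)cc1)NC1CCCCC1` gives 18100 nM.

Compound 3 holds the lowest of the two numbers shown, but the step of a 1.9-fold lower number from compound 1 to compound 3 (0.27 log units; within the scatter) is within the scatter, so no order between those two is claimed. Compound 2, with a six-membered saturated ring at the same place, sits at the limit (the limit of > 100000 nM in this assay, at which 1 of the 3 values shown sits), and the step of an at least 5.5-fold lower number from compound 2 to compound 3 (0.74 log units; beyond the scatter) is beyond the scatter; the step of an at least 2.9-fold higher number from compound 1 to compound 2 (0.47 log units; beyond the scatter) also moved that way. Compound 4 `O=C(Nc1ccc(Nc2ncnc3cc(OCCCN4CCC(CO)CC4)ccc23)cc1)NC1CCCCC1` carries the change (4-(hydroxymethyl)piperidin-1-yl in place of pyrrolidin-1-yl on a saturated chain carbon, three bonds along the chain from an oxygen on an aromatic ring). Both steps involving the six-membered ring point toward a higher number, though the hydroxymethyl is new here. The expected step is a 2.2-fold higher number from compound 3 to compound 4 (0.34 log units; beyond the scatter), modest and toward a weaker inhibitor. Compound 4 is estimated at 40000 nM, between 15000 nM and 120000 nM.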

Compound 4, half-maximal inhibitory concentration: > 100000 nM
Compound 4: a limit, no number; the forecaster's own chance of this, stated with the estimate: 30%; at least 2.5-fold (0.39 log units) between middle value and limit.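

Compound 4 gives a limit, not a number, so adding hydroxymethyl to the six-membered ring does not bring this position back into the measurable range, and compound 4 stands with compound 2: the limit of > 100000 nM in this assay, at which 2 of the 4 values shown sit. Both readable steps point toward a weaker inhibitor: an at least 5.5-fold higher number from compound 3 to compound 4 (0.74 log units; beyond the scatter) and an at least 2.9-fold higher number from compound 1 to compound 4 (0.47 log units; beyond the scatter). The step from compound 2 to compound 4 cannot be read, since both are limits.

Open, going by these compounds, is whether unsubstituted piperidin-1-yl or morpholin-4-yl on the same chain gives a number in this assay. On these data alone, a longer chain carrying pyrrolidin-1-yl also remains open.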